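Phenyl to 4-methoxyphenyl in the series

A few compounds are considered here, and "the series" means these few. Any claim that something is new, unique, unknown or untested is made for them only; others in the source may bear on it.

In a functional assay on HSC-4 cells (Homo sapiens) for cytotoxicity, with a stated time of 24 h (on this read-out higher numbers stand for lower toxicity in this test and lower numbers for higher toxicity in this test), compound 1 (`O=C1/C(=C/c2ccc(Cl)cc2)CCC/C1=C\c1cccc([N+](=O)[O-])c1`) gives 2300 nM and compound 2 (`O=C1/C(=C/c2ccccc2)CCC/C1=C\c1ccc([N+](=O)[O-])cc1`) gives 9200 nM. Compound 2 therefore holds the higher of the two numbers, with a gap beyond the scatter. Compound 3 (`COc1ccc(/C=C2\CCC/C(=C\c3ccc([N+](=O)[O-])cc3)C2=O)cc1`) carries methoxy in place of hydrogen on an aromatic carbon, para to a large group: methoxy in place of hydrogen on an aromatic carbon. Among the compounds with values here, no measured pair shows this change alone. Within the data shown here, a number below that of compound 2 is tentatively expected, since the only other measurement is compound 1 at 2300 nM. The expected change is a 1.8-fold lower number from compound 2 to compound 3 (0.26 log units; within the scatter), close to the scatter. For compound 3 the estimate is 5000 nM, with an expected range of 1800 nM to 14000 nM.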

Compound 3, half-maximal cytotoxic concentration: > 400000 nM
Compound 3: only a limit was reported; the forecaster's own chance of this, stated with the estimate: 3%; middle value at least 80-fold (1.90 log units) from the limit.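

In this assay, within the data shown here, phenyl to 4-methoxyphenyl gives an at least 43-fold higher number from compound 2 to compound 3 (1.63 log units; beyond the scatter), the first reading of a single change, and it shows that this position can move the read-out by a wide margin. Compounds 1 and 2 differ in more than one place, so they could not isolate this position. The entry for compound 3 is a limit and not a number: the limit of > 400000 nM in this assay, at which 1 of the 3 values shown sits.

Open, from the compounds shown here alone, is whether this step belongs to methoxy specifically or to substitution at this position generally. A hydroxyl group, an amine or a longer alkoxy chain in the same place would test this.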